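A few compounds are considered here, and "the series" means these few. Any claim that something is new, unique, unknown or untested is made for them only; others in the source may bear on it.

In a functional assay on DU-145 cells (Homo sapiens) for antiproliferative activity, read by sulforhodamine B assay, with a stated time of 72 h (on this read-out lower numbers stand for stronger inhibition and higher numbers for weaker inhibition), compound 1 `Cc1cc(C)nc(NS(=O)(=O)c2ccc(Nc3nncc4ccccc34)cc2)n1` gives 7.8 nM and sits in the middle of the three numbers in hand: compound 2 `C(=C/c1ccccc1)\C(=N\Nc1nncc2ccccc12)c1ccccc1` gives 1.3 nM on the lower side and compound 3 `S=C(NNc1nncc2ccccc12)Nc1ccccc1` gives 45 nM on the higher side, each gap beyond the scatter. Within the data shown here, those two compounds differ from compound 1 in more than one place, so no measured step bears directly on compound 4 `O=S(=O)(Nc1ncccn1)c1ccc(Nc2nncc3ccccc23)cc1` here. Compound 4 has pyrimidin-2-yl in place of 4,6-dimethylpyrimidin-2-yl on a sulfonamide nitrogen. In this assay no change beyond the scatter is expected, and the estimated step (a 1.3-fold higher number from compound 1 to compound 4 (0.11 log units; within the scatter)) is small, towards a higher number. Compound 4 is expected at 10 nM (estimated range 3.5 nM to 30 nM).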

Compound 4, half-maximal inhibitory concentration: 45 nM
Compound 4: middle estimate off by 4.5-fold (0.65 log units), on the low side, and the stated range ends below it.
By their numbers in this assay, from the lowest: compound 2; then compound 1; then compounds 3 and 4 (each within the scatter of the next).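

In this assay, among these compounds, pyrimidin-2-yl in place of 4,6-dimethylpyrimidin-2-yl gives a 5.8-fold higher number from compound 1 to compound 4 (0.76 log units; beyond the scatter), the only measured step. The sulfonamide nitrogen substituent therefore affects the read-out, even when the change leaves the aromatic ring in place and removes only its methyl groups. The data at hand offer no explanation for this step. Going by these compounds, it remains open whether a single methyl group on the pyrimidine recovers the number of compound 1. Also open, on these data alone, is how ethyl or methoxy groups in place of those methyl groups would read.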